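Swapping furan-2-yl for 2-chlorophenyl in a narrow series

The source may hold more compounds than are shown below. What is called first, only, known or untested is meant among the compounds shown, and "the series" means these compounds.

In a functional assay on microsomes for inhibition, with a stated time of 1 h (on this read-out lower numbers stand for stronger inhibition and higher numbers for weaker inhibition), compound 1 `CCOC(=O)c1cnn(-c2nc(-c3ccc(OC)cc3)c(C#N)c(=O)n2C)c1N` gives 68 ug/mL, compound 2 `CCOC(=O)c1cnn(-c2nc(-c3ccccc3F)c(C#N)c(=O)n2C)c1N` gives 94 ug/mL and compound 3 `CCOC(=O)c1cnn(-c2nc(-c3ccco3)c(C#N)c(=O)n2C)c1N` gives 116 ug/mL. These numbers lie within the usual scatter of one another, so compound 3 cannot be separated from the other two. Compound 4 `CCOC(=O)c1cnn(-c2nc(-c3ccccc3Cl)c(C#N)c(=O)n2C)c1N` carries 2-chlorophenyl in place of furan-2-yl on an aromatic carbon. Two measured steps at this place bear on it, a 1.2-fold higher number from compound 2 to compound 3 (0.09 log units; within the scatter) and a 1.7-fold higher number from compound 1 to compound 3 (0.23 log units; within the scatter), and both stay within the scatter. Compound 2, with its 2-fluorophenyl, is the nearest measured match and gives 94 ug/mL, so no step beyond the scatter is expected in this assay. The expected change is a 1.3-fold lower number from compound 3 to compound 4 (0.11 log units; within the scatter). For compound 4 the estimated value is 90 ug/mL, with an expected range from 50 ug/mL to 160 ug/mL.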

Compound 4, half-maximal inhibitory concentration: 102 ug/mL
Compound 4: middle estimate off by 1.1-fold (0.05 log units), on the low side; the range from low to high includes it.
By their numbers in this assay, from the lowest: compounds 1, 2, 4 and 3 (each within the scatter of the next).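

In this assay, 2-chlorophenyl and furan-2-yl cannot be told apart at this place (a 1.1-fold lower number from compound 3 to compound 4 (0.06 log units; within the scatter)). Chloro and fluoro on the aromatic ring also read alike (a 1.1-fold higher number from compound 2 to compound 4 (0.04 log units; within the scatter)), as do 2-chlorophenyl and 4-methoxyphenyl (a 1.5-fold higher number from compound 1 to compound 4 (0.18 log units; within the scatter)). No measured evidence offers a reason for this flat picture.

Every group shown at this place is an aromatic ring, so the effect of an amine, a carboxylic acid or a longer alkyl chain there remains open. Whether any group at this place can move the number beyond the scatter also stays unanswered.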